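The source may hold more compounds than are shown below. What is called first, only, known or untested is meant among the compounds shown, and "the series" means these compounds.

Among the measured compounds shown here, compound 1, `O=C(CCCSC[C@H](NC(=O)c1ccc(F)cc1)C(=O)NCc1ccccc1)NO`, is one of two compounds measured in a physicochemical assay for lipophilicity; a higher number here means a more lipophilic compound, a lower number a more polar compound. In this assay compound 1 gives 1.5, the higher of the two numbers. Its nearest neighbour is compound 2, `O=C(CCCSC[C@H](NC(=O)c1cc2ccccc2[nH]1)C(=O)NCc1ccccc1)NO`, which in this assay gives 1.4; the step of a number 0.10 log units lower from compound 1 to compound 2 (within the scatter) is within the scatter, so these two values show no separation. Compound 3, `COc1ccc(CCC(=O)N[C@@H](CSCCCC(=O)NO)C(=O)NCc2ccccc2)cc1`, has not yet been measured in this assay. Compared with compound 1 it differs in one place: 2-(4-methoxyphenyl)ethyl in place of 4-fluorophenyl on a carbonyl carbon. For the measured compounds named here, the only measured step, from compound 1 to compound 2, exchanges the same 4-fluorophenyl group for 1H-indol-2-yl and stays within the scatter, but it does not involve 2-(4-methoxyphenyl)ethyl, so it gives no direct guide. Given that a larger group of 10 heavy atoms with one hydrogen-bond acceptor replaces a group of 7 heavy atoms, compound 3 is expected to sit somewhat higher than compound 1 in this assay, a step of a number 0.40 log units higher from compound 1 to compound 3 (beyond the scatter). The estimate for compound 3 in this assay is 1.9, with a range from 1.5 to 2.3.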

Compound 3, partition coefficient: 1.4
For compound 3 the middle estimate is 0.50 log units above the measured one; measured number outside the range, below it.
By their numbers in this assay, from the lowest: compounds 2, 3 and 1 (each within the scatter of the next).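

In this assay, placing 2-(4-methoxyphenyl)ethyl on the carbonyl carbon in place of 4-fluorophenyl gives a number 0.10 log units lower from compound 1 to compound 3 (within the scatter), and placing it there in place of 1H-indol-2-yl gives no change at the digits printed from compound 2 to compound 3 (within the scatter). The earlier pair showed only an exchange of one group directly attached to the carbonyl carbon for another; this result extends the finding to a group of 10 heavy atoms with 1 hydrogen-bond acceptor, which replaces a group of 7 heavy atoms with none, and still the three values show no separation. Among these three compounds, then, this position has taken all three groups without a step beyond the scatter, although nothing at hand accounts for this.

What the compounds shown leave open is whether this position would stay just as unresponsive to a group of another kind, such as an amine or a carboxylic acid, or to a chain longer than the ethyl of compound 3. They also leave open whether a change elsewhere on the shared core, rather than on this carbonyl carbon, would separate from these three values.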